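Swapping Methoxycarbonyl for Phenyl on a Carbonyl Carbon

The source may hold more compounds than are shown below. What is called first, only, known or untested is meant among the compounds shown, and "the series" means these compounds.

Compound 1 `COc1cc(/C=C/C(=O)c2cccc(NC(=O)c3cccs3)c2)ccc1O`: 14.7 ug/mL
Compound 2 `COC(=O)C(=O)Nc1cccc(C(=O)/C=C/c2ccc(O)c(OC)c2)c1`: 12.2 ug/mL

Going by the values given here, in a functional assay on U-87MG ATCC cells (Homo sapiens) for inhibition (on this read-out lower numbers stand for stronger inhibition and higher numbers for weaker inhibition), compound 2 gives 12.2 ug/mL, which lies within the usual scatter of compound 1, the only other compound measured so far. The next compound, compound 3 `COc1cc(/C=C/C(=O)c2cccc(NC(=O)c3ccccc3)c2)ccc1O`, carries phenyl in place of methoxycarbonyl on a carbonyl carbon. Among the compounds with values here, only one measured step bears on this change: a 1.2-fold lower number from compound 1 to compound 2 (0.08 log units; within the scatter). It exchanges thiophen-2-yl for methoxycarbonyl on the same carbonyl carbon, so it shows a ring and the methoxycarbonyl group giving values within the scatter of each other. Two compounds are thin evidence, but they give no reason to expect a large shift in this assay. The expected change is a 1.1-fold higher number from compound 2 to compound 3 (0.06 log units; within the scatter), which means no expected step beyond the scatter and no firm direction. For compound 3 the estimated value is 14 ug/mL, with an expected range of 7 ug/mL to 28 ug/mL.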

Compound 3, half-maximal inhibitory concentration: 8.82 ug/mL
Compound 3: middle estimate off by 1.6-fold (0.20 log units), on the high side, and the stated range covers the measured number.
By their numbers in this assay, from the lowest: compounds 3, 2 and 1 (each within the scatter of the next).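

In this assay there is now a third group to compare on this carbonyl carbon, and the change to phenyl gives a 1.4-fold lower number from compound 2 to compound 3 (0.14 log units; within the scatter) while the direct comparison of the two rings gives a 1.7-fold lower number from compound 1 to compound 3 (0.22 log units; within the scatter). All three pairs among these compounds therefore lie within the scatter, so neither ring differs measurably from methoxycarbonyl here, and the two rings do not differ measurably from each other, even though phenyl brings a six-membered aromatic ring of carbon only and methoxycarbonyl brings no ring at all. Nothing available here explains the small spread of these numbers.

Still open, as far as these compounds go, is whether any group on this carbonyl carbon can produce a step beyond the scatter. An amine, a carboxylic acid or a longer chain in this place would test that.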